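The source may hold more compounds than are shown below. What is called first, only, known or untested is meant among the compounds shown, and "the series" means these compounds.

Measured compounds:
- Compound 1, `COc1ccc(C(=O)Nc2ccc(Cl)cc2F)c(OC)c1`, in an ADME assay on RAW264.7 cells (Mus musculus) for cytotoxicity, read by MTT assay, with a stated time of 24 h (on this read-out lower numbers stand for higher toxicity in this test and higher numbers for lower toxicity in this test), compound 1 gives 13600 nM.
- Compound 2, `COc1ccc(C(=O)Nc2ccc(Cl)cc2F)c(OCc2ccc(F)cc2F)c1`, in this assay compound 2 gives > 40000 nM, which is a limit of the assay and not a number.
- Compound 3, `COc1ccccc1C(=O)Nc1ccc(I)cc1F`, in this assay compound 3 gives > 40000 nM, again a limit of the assay and not a number.

Compound 1 and compound 2 share a core and differ only by 2,4-difluorophenyl in place of hydrogen on a saturated chain carbon bound to an oxygen on an aromatic ring. This change made an at least 2.9-fold higher number from compound 1 to compound 2 (0.46 log units; beyond the scatter); its true size is open because the limit of > 40000 nM in this assay, at which 2 of the 3 values shown sit, caps what the assay reports for compound 2. The difference between the core of compound 1 and the core of compound 3 is not broken down here.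

Compound 4, `O=C(Nc1ccc(I)cc1F)c1ccccc1OCc1ccc(F)cc1F`, is not yet measured. It differs from compound 3 by 2,4-difluorophenyl in place of hydrogen on a saturated chain carbon bound to an oxygen on an aromatic ring, the same change as that from compound 1 to compound 2, at the same place. Since compound 3 already sits at a limit of the assay, the change cannot raise its reported number further; the expected step is a number no higher from compound 3 to compound 4 (the limit leaves the size open), resting on the direction of an at least 2.9-fold higher number from compound 1 to compound 2 (0.46 log units; beyond the scatter), which points away from higher toxicity. Compound 4 is therefore expected to land at 40000 nM in this assay, most likely as a further limit, with the plausible range taken as 20000 nM to 80000 nM.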

Compound 4, half-maximal cytotoxic concentration: 32600 nM
The estimate for compound 4 lay 1.2-fold (0.09 log units) above the measured number; the measured number falls inside the stated range.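

In this assay, placing 2,4-difluorophenyl in place of hydrogen on a saturated chain carbon bound to an oxygen on an aromatic ring gives an at least 1.2-fold lower number from compound 3 to compound 4 (0.08 log units; that floor lies within the scatter), and this step does not match the one seen on the other core: the same change on two cores in this assay, an at least 2.9-fold higher number (0.46 log units; beyond the scatter) from compound 1 to compound 2 and an at least 1.2-fold lower number (0.08 log units; that floor lies within the scatter) from compound 3 to compound 4, at least 3.6-fold (0.55 log units) apart, beyond the scatter of two such steps

Neither step has a known true size, because each has one end at a value that is a limit of the assay and not a number: the limit of > 40000 nM in this assay, at which 2 of the 4 values shown sit.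

Going by these compounds alone, the two pairs show that the outcome of this change did not carry over unchanged from the core of compound 1 to the core of compound 3 in this test, but they do not show which feature of the cores accounts for the gap, and with only two cores they give no rule for the wider series.

The cores differ in more than one place, so the pairs shown do not separate the chlorine of compound 1 from the iodine of compound 3, nor the effect of the second methoxy group found only on the core of compound 1. Also open, on these data alone, is how this test would respond on either core if the 2,4-difluorophenyl were replaced by an unsubstituted phenyl, an amine or a carboxylic acid.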